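Bromo in Place of Fluoro on the Pyridyl Arm

This account rests on a few compounds, and the source may have more. Where it says the series, first, only, none or still open, it means among the compounds named here.

Compound 2 `Fc1ccc(-c2cc(OC[C@@H]3CCCN3)cnc2Cl)cn1` and compound 1 `Clc1ncc(OC[C@@H]2CCN2)cc1-c1ccc(Br)nc1` are the two measured compounds. In an assay on membranes from brain with Neuronal acetylcholine receptor; alpha4/beta2 (Rattus norvegicus) as the target (a lower number here means a stronger inhibitor, a higher number a weaker inhibitor), compound 1 gives 0.0043 nM, while compound 2 gives 0.0179 nM, the higher of the two numbers, so compound 2 is the weaker of the pair, and the gap lies beyond the scatter. Among the measured compounds shown here, the two structures differ in more than one place, so no single step joins them. Compound 3 `Clc1ncc(OC[C@@H]2CCCN2)cc1-c1ccc(Br)nc1` keeps the core of compound 2 and alters only one thing: bromo in place of fluoro on an aromatic carbon. For the measured compounds named here, no measured pair shows exactly this exchange. Compound 1, however, also carries the bromo group and gives 0.0043 nM, a lower number than compound 2. The step of a 2.0-fold lower number from compound 2 to compound 3 (0.30 log units; within the scatter) is therefore expected to lower the number, though perhaps not beyond the scatter. Compound 3 is expected to give 0.009 nM in this assay, with a range from 0.003 nM to 0.025 nM.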

Compound 3, inhibition constant: 0.0195 nM
Compound 3: the middle estimate sits 2.2-fold (0.34 log units) below what was measured; the measured number falls inside the stated range.
By their numbers in this assay, from the lowest: compound 1; then compounds 2 and 3 (each within the scatter of the next).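

In this assay, the exchange of 6-fluoropyridin-3-yl for 6-bromopyridin-3-yl gives a 1.1-fold higher number from compound 2 to compound 3 (0.04 log units; within the scatter) and so leaves fluoro and bromo indistinguishable at this place next to the ring nitrogen, at least with the pyrrolidin-2-yl side chain. With bromo held fixed, pyrrolidin-2-yl in place of azetidin-2-yl gives a 4.5-fold higher number from compound 1 to compound 3 (0.66 log units; beyond the scatter) and is a modest step, so within this pair the number moves with the saturated ring and not with any halogen exchange. No supporting data bear on the reason for either step.

As far as these compounds go, whether fluoro and bromo also read alike with the azetidin-2-yl side chain remains open. So does the outcome at this same place for a methoxy group, an amine or a nitrile, none of which appears among these compounds.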